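Amide replacement in the paw edema series

The source may report more compounds than this note shows. Statements on the series, on what has been measured and on what is new or still open speak of the compounds shown alone.

Compound 1 `CCN(CC)C(=O)CC1CCc2cc(OC)c(OC)cc21` and compound 2 `COc1cc2c(cc1OC)C(CC(=O)NC(C)(C)C)CC2` share one core and differ only in the amine on the carbonyl carbon. In a functional assay on the whole organism (strain Wistar) for inhibition, with Rattus norvegicus as the target, read by paw edema, with stated times of 60 min and 2 h, at a dose of 100 mg/kg by the oral route (a lower number here means less inhibition, a higher number more inhibition at the dose given (going by the name of the read-out)), compound 1 gives 40%, and compound 2 gives 32%. Within the data shown here, the single measured step, a number 8 percentage points lower from compound 1 to compound 2 (within the scatter), came with (tert-butyl)amino in place of diethylamino on a carbonyl carbon, so compound 2 sits with compound 1 inside the scatter of each other, and the two numbers do not separate. Compound 3 `COc1cc2c(cc1OC)C(CC(=O)N1CCNCC1)CC2` carries the change (piperazin-1-yl in place of (tert-butyl)amino on a carbonyl carbon). Among the measured compounds shown here, only the step from compound 1 to compound 2 bears on it, as that step also exchanged the amine on the carbonyl carbon, and it stayed within the scatter; no measured step brings a ring into this position. The expected step is therefore a number 3 percentage points higher from compound 2 to compound 3 (within the scatter), nothing beyond the scatter. Compound 3 is estimated at 35%, with a range from 15% to 55%.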

Compound 3, a percentage reported as inhibition, in the whole organism at one dose (the size of the read-out at that dose, not a potency): 44%
Beside the measured number, compound 3's estimate is 9 percentage points below it; low and high end bracket the measured number.
By their numbers in this assay, from the lowest: compounds 2, 1 and 3 (each within the scatter of the next, the first and the last beyond it).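

In this assay, the exchange of amines on the carbonyl carbon now gives a step beyond the scatter: a number 12 percentage points higher from compound 2 to compound 3 (beyond the scatter) with piperazin-1-yl in place of (tert-butyl)amino. The same ring set against diethylamino gives a number 4 percentage points higher from compound 1 to compound 3 (within the scatter) and does not separate, so the position responds only in the comparison with (tert-butyl)amino, and modestly. No available evidence bears on this result.

The compounds shown leave open whether the step goes with the six-membered ring itself or with its second nitrogen; piperidin-1-yl or morpholin-4-yl on the same carbonyl carbon would separate these two readings. Also open, as far as these compounds go, is how a primary amide or a longer chain carrying a terminal amine would compare at this position.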